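Adding chlorine to the phenyl ring of compound 2

The source may hold more compounds than are shown below. What is called first, only, known or untested is meant among the compounds shown, and "the series" means these compounds.

Three pyrazoline-bearing analogues have been measured in a functional assay on HT-29 cells (Homo sapiens) for antiproliferative activity, with a stated time of 72 h; on this read-out lower numbers stand for stronger inhibition and higher numbers for weaker inhibition. Compound 1 `COc1ccc(C2CC(c3ccc(Cl)cc3)=NN2c2nc(-c3ccccc3)c(C#N)c(=O)n2C)cc1` gives 9120 nM. Compound 2 `COc1ccc(C2=NN(c3nc(-c4ccccc4)c(C#N)c(=O)n3C)C(c3ccc(OC)cc3)C2)cc1` gives 9420 nM, which is the second highest of the three numbers; the step of a 1.0-fold higher number from compound 1 to compound 2 (0.01 log units; within the scatter) is within the scatter, so these two compounds cannot be told apart. Compound 3 `Cn1c(N2N=C(c3ccccc3)CC2c2ccc(F)cc2)nc(-c2ccc(Cl)cc2)c(C#N)c1=O` gives 13700 nM, and its gap to compound 2 is also within the scatter.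

Compound 4 `COc1ccc(C2=NN(c3nc(-c4ccc(Cl)cc4)c(C#N)c(=O)n3C)C(c3ccc(OC)cc3)C2)cc1` differs from compound 2 in one place: chloro in place of hydrogen on an aromatic carbon. Cut one bond further out, the change reads phenyl to 4-chlorophenyl, the group sitting on the shared core. For the measured compounds named here, no measured pair isolates this single change, so no step bears on it directly. Compound 3 carries the same 4-chlorophenyl on its core yet differs from compound 2 in further places; its value and that of compound 2 sit within the scatter of each other. With nothing pointing either way, compound 4 is expected to give a number close to compound 2, a step of a 1.1-fold higher number from compound 2 to compound 4 (0.03 log units; within the scatter) that stays within the scatter. The estimate for compound 4 in this assay is 10000 nM, with a range from 4000 nM to 25000 nM.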

Compound 4, half-maximal inhibitory concentration: 18200 nM
Estimate against measurement, compound 4: 1.8-fold (0.26 log units) below, within the range that was stated.
By their numbers in this assay, from the lowest: compounds 1, 2, 3 and 4 (each within the scatter of the next).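

In this assay, replacing phenyl with 4-chlorophenyl on the shared core gives a 1.9-fold higher number from compound 2 to compound 4 (0.29 log units; within the scatter) and is therefore too small to separate from repeat-measurement scatter. For the compounds shown here, this pair is the first to isolate the change, which the earlier compounds could address only alongside other differences. Here, a chloro on this six-membered aromatic ring, para to a large group, leaves no clear mark on antiproliferative activity, and no separate measurement is available to interpret the result.

This single pair cannot show whether chloro would behave the same way with different groups elsewhere on the shared core. It also leaves open whether a larger or very different group at this position, such as an amine, a carboxylic acid or a longer chain, would produce a step beyond the scatter.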